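A few compounds are considered here, and "the series" means these few. Any claim that something is new, unique, unknown or untested is made for them only; others in the source may bear on it.

Values in a functional assay on CCRF-CEM cells (Homo sapiens) for antiproliferative activity, read by MTT assay; on this read-out lower numbers stand for stronger inhibition and higher numbers for weaker inhibition:

- compound 1 `CC/C(=N\Nc1nc2ccccc2o1)c1ccccn1`: 4 nM
- compound 2 `C/C(=N\Nc1nc2ccccc2o1)c1ccccn1`: 15 nM
- compound 3 `C/C(=N\N(C)c1nc2ccccc2o1)c1ccccn1`: > 50000 nM, a limit of the assay

Of the two true numbers in hand, the higher belongs to compound 2 at 15 nM. The remaining result, that of compound 3, is only a limit.

Next in the series is compound 4 `C/C(=N\Nc1nc2ccccc2o1)c1cccnc1`, with pyridin-3-yl in place of pyridin-2-yl on a carbon with a double bond to nitrogen.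

Among the compounds with values here, no measured step touches this group, so the two available steps serve only as a rough guide to how much a single change can matter. On the saturated chain carbon the change gives a 3.8-fold higher number from compound 1 to compound 2 (0.57 log units; beyond the scatter). Methyl in place of hydrogen on a nitrogen gives an at least 3300-fold higher number from compound 2 to compound 3 (3.52 log units; beyond the scatter).

Given that spread, and with compound 2 already low on the scale, a higher number in this assay is expected, with a size somewhere between those two steps and poorly fixed.

The expected step is a 100-fold higher number from compound 2 to compound 4 (2.00 log units; beyond the scatter).

For compound 4 the estimate is 1500 nM, with an expected range of 60 nM to 30000 nM.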

Compound 4, half-maximal inhibitory concentration: > 100000 nM
Compound 4 gave a limit, no number (the forecaster's own chance of this, stated with the estimate: 15%); at least 66-fold (1.82 log units) between middle value and limit.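

In this assay, within the data shown here, the change from pyridin-2-yl to pyridin-3-yl on the carbon with a double bond to nitrogen gives an at least 6600-fold higher number from compound 2 to compound 4 (3.82 log units; beyond the scatter) and is the first measured step at this position. The two groups have the same atoms and the same printed counts of donors and acceptors, so the attachment point of the ring alone separates a low nanomolar compound from an inactive reading at the top of the tested range. Compound 4 gives > 100000 nM, a limit of the assay and not a number, and the full size of the step stays unfixed: the limit of > 100000 nM in this assay, at which 1 of the 4 values shown sits.

Going by these compounds, whether pyridin-4-yl or a plain phenyl ring at this place keeps any of the activity of compound 2 remains open. Also open, on these data alone, is whether the same change has a step of similar size on the ethyl chain of compound 1.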